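From compound 2 to compound 3: one amide substituent changes

A few compounds are considered here, and "the series" means these few. Any claim that something is new, unique, unknown or untested is made for them only; others in the source may bear on it.

Compound 1 `CNC(=O)c1ccncc1Nc1cc(-c2ccc3ccn(C)c3c2)c2nccnc2c1`: 4 ug/mL
Compound 2 `CN1CC(NC(=O)c2ccncc2Nc2cc(-c3ccc4ccn(C)c4c3)c3nccnc3c2)CCC1=O`: 253 ug/mL

Going by the values given here, in a physicochemical assay for solubility, read by spectrophotometry, measured as kinetic solubility, at pH 8, tested at 500 uM (on this read-out lower numbers stand for lower solubility and higher numbers for higher solubility), compound 2 gives 253 ug/mL, the higher of the two numbers known so far, while compound 1 gives 4 ug/mL. Compound 3 `Cn1ccc2ccc(-c3cc(Nc4cnccc4C(=O)NCC4COCCN4)cc4nccnc34)cc21` has not yet been measured. It keeps the shared core and differs from compound 2 only on an amide-type nitrogen, where (morpholin-3-yl)methyl stands in place of 1-methyl-6-oxopiperidin-3-yl ((morpholin-3-yl)methyl in place of 1-methyl-6-oxopiperidin-3-yl on an amide-type nitrogen).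

Among the compounds with values here, only one measured step bears on this place: a 63-fold higher number from compound 1 to compound 2 (1.80 log units; beyond the scatter), a large step beyond the scatter, with 1-methyl-6-oxopiperidin-3-yl in place of methyl. It shows that the number can move far with the group on this nitrogen. However, it compares a ring-bearing group with methyl, and no measurement yet compares two ring-bearing groups here. Compound 3 keeps a six-membered non-aromatic ring, so a repeat of a step that size is not expected. The expected change is a 1.3-fold lower number from compound 2 to compound 3 (0.10 log units; within the scatter), which is no step beyond the scatter. For compound 3 the estimated value is 200 ug/mL, with an expected range of 90 ug/mL to 270 ug/mL.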

Compound 3, solubility: 239 ug/mL
For compound 3 the middle estimate is 1.2-fold (0.08 log units) below the measured one; the range from low to high includes it.
By their numbers in this assay, from the lowest: compound 1; then compounds 3 and 2 (each within the scatter of the next).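

In this assay, going by these compounds alone, the first comparison of two ring-bearing groups on this amide-type nitrogen gives a 1.1-fold lower number from compound 2 to compound 3 (0.02 log units; within the scatter), so (morpholin-3-yl)methyl and 1-methyl-6-oxopiperidin-3-yl cannot be told apart on this read-out, although they differ in ring hetero atoms, in the link to the nitrogen and in the hydrogen-bond donor that only (morpholin-3-yl)methyl carries. The large rise seen with the first ring-bearing group is therefore not confined to that group: the methyl amide and the new compound are also far apart, with a 60-fold higher number from compound 1 to compound 3 (1.78 log units; beyond the scatter), and among the three compounds shown both groups with a six-membered non-aromatic ring stand well above methyl, with none going against this. No measurement is available that accounts for this result.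

As far as these compounds go, what remains open is whether the ring itself matters or whether a larger group on this nitrogen is enough, a question that a plain n-butyl chain or an open-chain dimethylaminoethyl group could address. From the compounds shown here alone, it is equally open whether a cyclohexyl ring, with no hetero atom at all, would stand with the two ring-bearing groups or nearer to methyl.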